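The source may report more compounds than this note shows. Statements on the series, on what has been measured and on what is new or still open speak of the compounds shown alone.

Measured in a functional assay on MCF7 cells (Homo sapiens) for cytotoxicity, read by MTT assay, with a stated time of 24 h; a lower number here means a stronger inhibitor, a higher number a weaker inhibitor:
compound 1 `Nc1cccn2cc(Cc3ccc(F)cc3)c(=O)nc12`: 135000 nM
compound 2 `O=c1nc2ccccn2cc1Cc1ccc(F)cc1C(F)(F)F`: 9870 nM
compound 3 `O=c1nc2ccc(Cl)cn2cc1Cc1ccc(F)cc1`: 10400 nM

Compound 3 gives 10400 nM, within the usual scatter of compound 2, and compound 1 lies beyond the scatter at a higher number. Compound 4 `O=c1nc2ccccn2cc1Cc1ccc(F)cc1`, not yet measured, differs from compound 3 by hydrogen in place of chloro on an aromatic carbon. Among the measured compounds shown here, no measured pair isolates this change. Compound 2 also lacks chloro and gives 9870 nM, while compound 1, likewise without chloro, gives 135000 nM. In this assay a modest move to a higher number is therefore expected, estimated as a 2.4-fold higher number from compound 3 to compound 4 (0.38 log units; beyond the scatter). The value expected for compound 4 is 25000 nM, with an estimated range of 9000 nM to 70000 nM.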

Compound 4, half-maximal inhibitory concentration: 200000 nM
Compound 4: the middle estimate sits 8.0-fold (0.90 log units) below what was measured; measured number outside the range, above it.
By their numbers in this assay, from the lowest: compounds 2 and 3 (each within the scatter of the next); then compounds 1 and 4 (each within the scatter of the next).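

In this assay the chloro on this aromatic carbon, two atoms from the ring nitrogen, proves to matter greatly, since hydrogen in its place gives a large step (a 19-fold higher number from compound 3 to compound 4 (1.28 log units; beyond the scatter)). Hydrogen in place of trifluoromethyl is also a large step (a 20-fold higher number from compound 2 to compound 4 (1.31 log units; beyond the scatter)), whereas hydrogen in place of amino stays within the scatter (a 1.5-fold higher number from compound 1 to compound 4 (0.17 log units; within the scatter)). No measurement at hand bears on why the chloro and trifluoromethyl steps are so large. Going by these compounds, whether bromo, methoxy or nitrile on the chloro-bearing carbon would keep the number close to that of compound 3 remains open.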